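A halogen swapped for a methyl on the amide ring

The source may report more compounds than this note shows. Statements on the series, on what has been measured and on what is new or still open speak of the compounds shown alone.

Compound 3 `NC(=O)c1c(NC(=O)c2ccccc2I)sc2c1CCN(C(=S)Nc1ccccc1C(F)(F)F)C2` is measured in a functional assay on HL-60 cells (Homo sapiens) for antiproliferative activity, with a stated time of 24 h (a higher number here means a weaker inhibitor, a lower number a stronger inhibitor), where compound 3 gives 19700 nM. Its close relatives are compound 2 `NC(=O)c1c(NC(=O)c2ccccc2Br)sc2c1CCN(C(=S)Nc1ccccc1C(F)(F)F)C2`, which in this assay gives 27400 nM, and compound 1 `Cc1ccccc1C(=O)Nc1sc2c(c1C(N)=O)CCN(C(=S)Nc1ccccc1Cl)C2`, which gives 20900 nM. All three numbers lie within the usual scatter of one another, so compound 3 cannot be set apart from the other two. Among the compounds with values here, the only single-point step among them, a 1.4-fold lower number from compound 2 to compound 3 (0.14 log units; within the scatter), shows that exchanging one halogen for another left the number where it was.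

Compound 4 `Cc1ccccc1C(=O)Nc1sc2c(c1C(N)=O)CCN(C(=S)Nc1ccccc1C(F)(F)F)C2` is not yet measured. It differs from compound 3 in one place: methyl in place of iodo on an aromatic carbon. Within the data shown here, no measured step covers exactly this exchange. The nearest guide is compound 1, which already carries the methyl group together with a different thiourea ring, and its value sits with those of compounds 2 and 3. The expected step, a 1.1-fold higher number from compound 3 to compound 4 (0.03 log units; within the scatter), is therefore one within the scatter. Compound 4 is estimated at 21000 nM, within a range of 10000 nM to 45000 nM.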

Compound 4, half-maximal inhibitory concentration: 23200 nM
Estimate against measurement, compound 4: 1.1-fold (0.04 log units) below; the range from low to high includes it.
By their numbers in this assay, from the lowest: compounds 3, 1, 4 and 2 (each within the scatter of the next).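

In this assay, methyl takes the place of iodo with a 1.2-fold higher number from compound 3 to compound 4 (0.07 log units; within the scatter), and it takes the place of bromo with a 1.2-fold lower number from compound 2 to compound 4 (0.07 log units; within the scatter), so at this aromatic carbon methyl cannot be told apart from either halogen. Within the data shown here, the compounds also give a first single-place reading on the other aromatic ring: with the methyl group held constant, trifluoromethyl takes the place of chloro with a 1.1-fold higher number from compound 1 to compound 4 (0.05 log units; within the scatter), which again stays within the scatter. Nothing available here accounts for these results.

From the compounds shown here alone, only methyl, bromo and iodo appear at the first carbon, so whether an amine, a carboxylic acid or a longer chain there would move the number remains open. On the other ring, only chloro and trifluoromethyl appear, which leaves groups such as methoxy untested by these compounds.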